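The source may report more compounds than this note shows. Statements on the series, on what has been measured and on what is new or still open speak of the compounds shown alone.

Measured compounds:
Compound 1, `CCCCCCCCCO[C@@H]1[C@@H](N)[C@@H](OCC(O)CO)O[C@H](CN)[C@H]1OCCCCCCCCC`, in a toxicity assay on the whole organism (J774 cells) for cytotoxicity, with Mus musculus as the target, read by MTT assay, with a stated time of 24 h, tested at 10 uM (on this read-out higher numbers stand for a weaker effect at the one concentration tested and lower numbers for a stronger effect), compound 1 gives 89.7%.
Compound 2, `CCCCCCCCCO[C@@H]1[C@@H](N)[C@@H](OCC(O)CNCCN)O[C@H](CN)[C@H]1OCCCCCCCCC`, in this assay compound 2 gives 87.5%.

Going by the values given here, these are the only two numbers so far. Among the compounds with values here, compound 2 has the lower of the two, but its one neighbour, compound 1, lies within the scatter of it, so the two compounds cannot be told apart; the step of a number 2.2 percentage points lower from compound 1 to compound 2 (within the scatter) confirms this.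

Compound 3, `CCCCCCCCCO[C@@H]1[C@@H](N)[C@@H](OCC(O)CNCCCN)O[C@H](CN)[C@H]1OCCCCCCCCC`, differs from compound 2 in one place: aminomethyl in place of amino on a saturated chain carbon, two bonds along the chain from an amine nitrogen. Within the data shown here, the only measured step, a number 2.2 percentage points lower from compound 1 to compound 2 (within the scatter), touched the same side chain and left the read-out unchanged beyond the scatter. Lengthening the chain by one further carbon is a smaller alteration still, so for compound 3 no step beyond the scatter is expected, a number 0.5 percentage points higher from compound 2 to compound 3 (within the scatter). Compound 3 is therefore estimated at 88%, expected to fall between 78% and 97%.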

Compound 3, a percentage reported as activity, at one concentration (the size of the read-out at that concentration, not a potency): 101%
Compound 3: the middle estimate sits 13 percentage points below what was measured; measured number outside the range, above it.
By their numbers in this assay, from the lowest: compounds 2 and 1 (each within the scatter of the next); then compound 3.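

In this assay, this saturated chain carbon, two bonds along the chain from an amine nitrogen, proves sensitive to a small edit: aminomethyl in place of amino gives a number 13.5 percentage points higher from compound 2 to compound 3 (beyond the scatter) and so points to a weaker effect at the one concentration tested. Replacing hydroxy with (3-aminopropyl)amino also leaves a gap, a number 11.3 percentage points higher from compound 1 to compound 3 (beyond the scatter), which the swap to (2-aminoethyl)amino did not do. Nothing measured here explains why the read-out moved.

The compounds shown leave open whether a longer chain, such as (4-aminobutyl)amino, would give a still higher number or fall back towards the lower values. They also leave open whether the amine of the new group matters, which (3-hydroxypropyl)amino in the same place would help to answer.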